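Compound 1 to compound 4: exchanging the aromatic group

The source may report more compounds than this note shows. Statements on the series, on what has been measured and on what is new or still open speak of the compounds shown alone.

Values in a functional assay on the whole organism for antagonist activity, with Mus musculus as the target; on this read-out lower numbers stand for an effect already at smaller amounts and higher numbers for an effect only at larger amounts of compound:
- compound 1 `CCC(=O)N(c1ccc(Cl)cc1)C1CCCCC1N(C)C`: 17 mg/kg
- compound 2 `CCC(=O)N(c1ccc(OC)cc1)C1CCCCC1N(C)C`: > 50 mg/kg (a limit, not a number)
- compound 3 `CCC(=O)N(c1cccc(C)c1)C1CCCC1N(C)C`: 1 mg/kg; 1 mg/kg (2 entries)

In this assay compound 1 gives 17 mg/kg, a higher number than compound 3 at 1 mg/kg; 1 mg/kg (2 entries). Compound 2 reaches only a limit, (the limit of > 50 mg/kg in this assay, at which 1 of the 3 values shown sits).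

Compound 4 `CCC(=O)N(c1cccc(C)c1)C1CCCCC1N(C)C` keeps the core of compound 1 and has 3-methylphenyl in place of 4-chlorophenyl on an amide-type nitrogen.

Among the measured compounds shown here, one measured step touches the same aromatic group: an at least 2.9-fold higher number from compound 1 to compound 2 (0.46 log units; beyond the scatter), with methoxy in place of chloro on an aromatic carbon. It shows that this assay responds to a change there on this core, but it does not involve 3-methylphenyl. That group occurs only in compound 3, on a different core, with 1 mg/kg; 1 mg/kg (2 entries). A modest move towards a lower number is therefore expected, and the expected step is a 2.4-fold lower number from compound 1 to compound 4 (0.39 log units; beyond the scatter). For compound 4 the estimate is 7 mg/kg, with an expected range from 2 mg/kg to 30 mg/kg.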

Compound 4, dose for half-maximal effect: 15 mg/kg
Compound 4: the middle estimate sits 2.1-fold (0.33 log units) below what was measured; measured number inside the range.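

In this assay the exchange gives a 1.1-fold lower number from compound 1 to compound 4 (0.05 log units; within the scatter), so on the shared core 3-methylphenyl and 4-chlorophenyl on the amide-type nitrogen cannot be told apart, whereas methoxy in place of chloro gives an at least 2.9-fold higher number from compound 1 to compound 2 (0.46 log units; beyond the scatter), a step that rests on a limit. 3-Methylphenyl does not by itself bring the low number: on the core of compound 1, compound 4 gives 15 mg/kg, while on its different core compound 3 gives 1 mg/kg; 1 mg/kg (2 entries). Nothing in the data at hand bears on the reason for this result.

Open, from the compounds shown here alone, is how the read-out on the shared core responds to an aromatic ring carrying an amine or a carboxylic acid, or to a longer chain in place of the methyl. Also open, going by these compounds, is whether the core of compound 3 keeps its low number with 4-chlorophenyl on the amide-type nitrogen.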